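The source may report more compounds than this note shows. Statements on the series, on what has been measured and on what is new or still open speak of the compounds shown alone.

Working notes on a small set of growth inhibitors. Compound 1 `O=C(/C(=C\c1ccc([N+](=O)[O-])c(O)c1)SCc1ccc(Br)cc1)c1c(F)c(F)c(F)c(F)c1F` and compound 2 `O=C(/C(=C\c1ccccc1OCc1ccccc1)S(=O)(=O)Cc1ccc(F)cc1)c1ccc(Cl)cc1` are the two measured comparators for compound 3 `Cc1ccc(S/C(=C/c2ccc(Cl)c(Cl)c2)C(=O)c2ccc(Br)cc2)cc1`. In a functional assay on DU-145 cells (Homo sapiens) for inhibition, read by trypan blue exclusion, with a stated time of 96 h (a lower number here means a stronger inhibitor of growth, a higher number a weaker inhibitor of growth), compound 1 gives 10000 nM, compound 2 gives 10000 nM, and compound 3 gives 50000 nM. Compound 3 thus carries the highest number of the three, and its gaps to compound 1 and to compound 2 both lie beyond the scatter. Compound 4 `COc1ccccc1/C=C(/Sc1ccc(C)cc1)C(=O)c1ccc(Br)cc1` keeps the core of compound 3 and differs in one place: 2-methoxyphenyl in place of 3,4-dichlorophenyl on a double-bonded chain carbon bound to a double-bonded chain carbon. Among the measured compounds shown here, no measured pair isolates this change, and compound 2 differs from compound 3 in more than one place, so neither value guides the step cleanly. The step of a 2.0-fold lower number from compound 3 to compound 4 (0.30 log units; within the scatter) is expected to be small, pointing toward a lower number if anywhere, and not clearly beyond the scatter. Compound 4 is therefore estimated at 25000 nM in this assay, with a likely range from 6000 nM to 100000 nM.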

Compound 4, concentration for 50% growth inhibition: 9000 nM
For compound 4 the middle estimate is 2.8-fold (0.44 log units) above the measured one; the range from low to high includes it.
By their numbers in this assay, from the lowest: compounds 4, 1 and 2 (each within the scatter of the next); then compound 3.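

Replacing 3,4-dichlorophenyl with 2-methoxyphenyl in this assay gives a 5.6-fold lower number from compound 3 to compound 4 (0.74 log units; beyond the scatter), the first evidence from a one-place change that the number responds to the aryl group at this position. The heavy-atom count stays the same, while the entering group brings one hydrogen-bond acceptor and the two chlorine atoms leave. No measurement available here explains the step.

Going by these compounds, it remains open whether the lower number follows the entering methoxy group or the departure of the chlorine atoms. A plain phenyl at this place would separate the two.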